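A few compounds are considered here, and "the series" means these few. Any claim that something is new, unique, unknown or untested is made for them only; others in the source may bear on it.

Measured in a functional assay on CWR22R cells (Homo sapiens) for antiproliferative activity, read by propidium iodide staining, with a stated time of 96 h; a higher number here means a weaker inhibitor, a lower number a stronger inhibitor:
- compound 1 `CC(O)(COc1cccc(S(F)(F)(F)(F)F)c1)C(=O)Nc1ccc(S(F)(F)(F)(F)F)cc1`: 17600 nM
- compound 2 `CC(O)(COc1cccc(C(F)(F)F)c1)C(=O)Nc1ccc(S(F)(F)(F)(F)F)cc1`: 14600 nM
- compound 3 `CC(O)(COc1cccc(OC(F)(F)F)c1)C(=O)Nc1ccc(S(F)(F)(F)(F)F)cc1`: 17300 nM

Compound 2 cannot be separated from the other two: a 1.2-fold lower number from compound 1 to compound 2 (0.08 log units; within the scatter), and a 1.2-fold higher number from compound 2 to compound 3 (0.07 log units; within the scatter). The remaining pair gives a 1.0-fold lower number from compound 1 to compound 3 (0.01 log units; within the scatter).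

The next change leads to compound 4 `CC(O)(COc1ccc(C#N)cc1)C(=O)Nc1ccc(S(F)(F)(F)(F)F)cc1`: 4-cyanophenyl in place of 3-(trifluoromethyl)phenyl on an oxygen on a saturated carbon.

Among the measured compounds shown here, the measured steps bear on this only loosely, as each replaces one fluorinated group with another, and no measured compound carries a nitrile. All three stayed within the scatter, so no step beyond the scatter is expected in this assay, in either direction, though with low confidence.

The estimated step is a 1.2-fold higher number from compound 2 to compound 4 (0.09 log units; within the scatter).

For compound 4 the expected value is 18000 nM, with an estimated range of 8000 nM to 40000 nM.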

Compound 4, half-maximal inhibitory concentration: 26100 nM
The estimate for compound 4 lay 1.5-fold (0.16 log units) below the measured number; low and high end bracket the measured number.
By their numbers in this assay, from the lowest: compounds 2, 3, 1 and 4 (each within the scatter of the next).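

Replacing 3-(trifluoromethyl)phenyl with 4-cyanophenyl on this oxygen gives, in this assay, a 1.8-fold higher number from compound 2 to compound 4 (0.25 log units; within the scatter) with no fluorine left on that ring. The flat picture among the fluorinated groups therefore extends to a nitrile, even with the substituent's ring number changed in the same step. No measurement on hand offers an explanation for this result.

3-Cyanophenyl and 4-(trifluoromethyl)phenyl would separate the group from its ring number. As far as these compounds go, whether an amine or a carboxylic acid in place of the nitrile would give a step beyond the scatter remains open.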